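The source may hold more compounds than are shown below. What is called first, only, known or untested is meant among the compounds shown, and "the series" means these compounds.

Compound 3 `Nc1cccc(-c2cn3nc(-c4ccccc4)sc3n2)c1` gives 26000 nM in a functional assay on HeLa cells (Homo sapiens) for inhibition, read by cell counting, with a stated time of 4 days (on this read-out lower numbers stand for stronger inhibition and higher numbers for weaker inhibition), the highest of the two numbers at hand. Compound 1 `Nc1cccc(-c2cn3nc(-c4cccs4)sc3n2)c1` gives only a limit in this assay, > 250000 nM. Compound 2 `CCc1ccc(-c2nn3cc(-c4cccc(N)c4)nc3s2)cc1` gives 8100 nM. Two measured steps lead to compound 3: an at least 9.6-fold lower number from compound 1 to compound 3 (0.98 log units; beyond the scatter), and a 3.2-fold higher number from compound 2 to compound 3 (0.51 log units; beyond the scatter). Compound 4 `Nc1cccc(-c2cn3nc(-c4ccc(Cl)cc4)sc3n2)c1` differs from compound 3 by chloro in place of hydrogen on an aromatic carbon. The nearer comparison is the ethyl step, because a 3.2-fold higher number from compound 2 to compound 3 (0.51 log units; beyond the scatter) also concerns a group on the phenyl ring of the shared core; a modest lowering of the number is therefore expected, the step of a 2.6-fold lower number from compound 3 to compound 4 (0.41 log units; beyond the scatter) from compound 3 to compound 4 being estimated in the direction of stronger inhibition. Compound 4 is estimated at 10000 nM, with a range of 3500 nM to 30000 nM.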

Compound 4, half-maximal inhibitory concentration: 160000 nM
Beside the measured number, compound 4's estimate is 16-fold (1.20 log units) below it, and the stated range ends below it.
By their numbers in this assay, from the lowest: compound 2; then compound 3; then compound 4. At a limit, above all of these: compound 1.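

Phenyl to 4-chlorophenyl gives a 6.2-fold higher number from compound 3 to compound 4 (0.79 log units; beyond the scatter), which is weaker inhibition. Hydrogen in place of ethyl gives a 3.2-fold higher number from compound 2 to compound 3 (0.51 log units; beyond the scatter), so ethyl went with stronger inhibition, and a group at this place, para to a large group, does not always go with stronger inhibition. Chloro against ethyl at the same place gives a 20-fold higher number from compound 2 to compound 4 (1.30 log units; beyond the scatter), so the outcome depends on which group enters. 4-Chlorophenyl in place of thiophen-2-yl gives an at least 1.5-fold lower number from compound 1 to compound 4 (0.19 log units; that floor lies within the scatter). This step cannot be read further, as compound 1 stands at a limit: the limit of > 250000 nM in this assay, at which 1 of the 4 values shown sits.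

Open, on these data alone, is how a methoxy group, an amine or a carboxylic acid at this place would read. Also open, as far as these compounds go, is whether a chain longer than ethyl would extend the gain seen with ethyl.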